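The source may hold more compounds than are shown below. What is called first, only, known or untested is meant among the compounds shown, and "the series" means these compounds.

Series notes on the shared core, carrying different groups at one place. In an ADME assay on microsomes from liver (Mus musculus) for metabolic stability, with a stated time of 10 min (on this read-out higher numbers stand for a more stable compound and lower numbers for a less stable compound), compound 1 (`Cc1c(Cl)cccc1Oc1cccn2c([C@]34CCC(C[C@H]3O)C4(C)C)nnc12`) gives 21% and compound 2 (`CC(=O)N1CCC(c2nnc3c(Oc4cccc(Cl)c4C)cccn23)CC1`) gives 90%. Compound 2 therefore stands at the top of the two numbers available, and its gap to compound 1 lies well beyond the scatter. Compound 3 (`Cc1c(Cl)cccc1Oc1cccn2c(C34CCC(N)(CC3)CC4)nnc12`) adds no number, as its entry reads "not determined" (no result reported).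

The next step starts from compound 2 and leads to compound 4 (`Cc1c(Cl)cccc1Oc1cccn2c(C34CCC(O)(CC3)CC4)nnc12`), which has not yet been measured. The change is a group of 9 heavy atoms (8 carbon, 1 oxygen; 2 six-membered non-aromatic rings of carbon only) in place of a group of 9 heavy atoms (7 carbon, 1 nitrogen, 1 oxygen; one six-membered non-aromatic ring with 1 hetero atom), on an aromatic carbon. Among the compounds with values here, no measured pair differs in one place only, so no direct precedent exists for the size of this step. Compound 1, at 21%, also carries carbon-only rings with oxygen at this place, and this points downward from compound 2, though the group in compound 1 is not the same. A fall beyond the scatter is therefore expected, but only a partial one towards compound 1. The expected change is a number 30 percentage points lower from compound 2 to compound 4 (beyond the scatter). For compound 4 the estimate is 60%, with an expected range from 35% to 85%.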

Compound 4, percent of the compound remaining: 96%
Beside the measured number, compound 4's estimate is 36 percentage points below it, outside the stated range (above it).
By their numbers in this assay, from the lowest: compound 1; then compounds 2 and 4 (each within the scatter of the next).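

In this assay the 1-acetylpiperidin-4-yl group and the group with 2 six-membered non-aromatic rings of carbon only, on the aromatic carbon between two ring nitrogen atoms, cannot be told apart: the exchange reads as a number 6 percentage points higher from compound 2 to compound 4 (within the scatter) and adds 1 hydrogen-bond donor while the reading stays inside the usual spread of repeats. Carbon-only rings with oxygen at this place therefore do not on their own go with a low number, as compound 1 gives 21% and compound 4 gives 96% in the same test, so the low reading of compound 1 cannot be assigned to those features alone. No measurement shown explains why the two groups read alike here.

On these data alone, it remains open whether a carboxylic acid or a methyl ether in place of the hydroxyl on the carbon-only rings would keep the reading of compound 4 in this assay or bring it down towards that of compound 1. As far as these compounds go, it also remains open whether a smaller group at this place, such as a cyclopropyl ring or a plain methyl, would read like compound 2 and compound 4.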